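Lengthening the hydroxamate chain of compound 1

The source may hold more compounds than are shown below. What is called first, only, known or untested is meant among the compounds shown, and "the series" means these compounds.

Of the compounds shown here, three have been measured in a functional assay on MCF7 cells (Homo sapiens) for inhibition, read by MTT assay; on this read-out lower numbers stand for stronger inhibition and higher numbers for weaker inhibition. Compound 1, with the structure `CC(C)=CCC/C(C)=C/CC/C(C)=C/CSc1ccccc1C(=O)NCCC(=O)NO`, gives 4930 nM in this assay, the highest number of the three. Compound 2, with the structure `COc1ccc(/C=C/C(=O)c2ccc(OCC(=O)NO)cc2)cc1`, gives 620 nM in this assay, and compound 3, with the structure `O=C(CCCCCCC(=O)Nc1nnc(-c2ccc(Br)o2)s1)NO`, gives 880 nM in this assay. Compound 1 thus stands apart from both, and the gaps to compound 3 and to compound 2 both lie beyond the scatter of repeated measurements, so compound 1 is the weakest inhibitor among the three measured compounds.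

Compound 4, with the structure `CC(C)=CCC/C(C)=C/CC/C(C)=C/CSc1ccccc1C(=O)NCCCC(=O)NO`, has not yet been measured. It differs from compound 1 in one place: (hydroxycarbamoyl)methyl in place of hydroxycarbamoyl on a saturated chain carbon, two bonds along the chain from an amide-type nitrogen. The change adds one saturated chain carbon between the amide-type nitrogen and the hydroxycarbamoyl group; the hydrogen-bond donors and acceptors stay the same in number.

Going by the values given here, no pair of measured compounds shows this single change, so no measured step can guide the expectation. For compound 4 a small step toward a lower number in this assay is expected, as a 1.5-fold lower number from compound 1 to compound 4 (0.19 log units; within the scatter), which may well lie within the scatter. The estimate for compound 4 in this assay is 3200 nM, within a range from 1000 nM to 10000 nM.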

Compound 4, half-maximal inhibitory concentration: 4930 nM
Estimate against measurement, compound 4: 1.5-fold (0.19 log units) below, within the range that was stated.
By their numbers in this assay, from the lowest: compounds 2 and 3 (each within the scatter of the next); then compounds 1 and 4 (each within the scatter of the next).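

In this assay, going by these compounds alone, the one-carbon extension gives no change at the digits printed from compound 1 to compound 4 (within the scatter) and offers the first direct reading of a single change, since the earlier compounds differ from one another in more than one place. At this position, on a saturated chain carbon, two bonds along the chain from an amide-type nitrogen, putting (hydroxycarbamoyl)methyl in place of hydroxycarbamoyl therefore leaves the read-out where it was, with the same count of hydrogen-bond donors and acceptors on both groups. Nothing in the available information explains this flat result, so the lack of a step stands here as an observation only.

One added saturated carbon is a single point, so it cannot show how the read-out would respond to a still longer chain or whether this flat stretch continues beyond compound 4. It also leaves open what a carboxylic acid in place of the hydroxycarbamoyl group would do on either chain length, which would test the end group rather than the length of the chain that carries it.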